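Pyridin-3-yl in Place of 4-Bromophenyl on the Chain

The source may report more compounds than this note shows. Statements on the series, on what has been measured and on what is new or still open speak of the compounds shown alone.

Three compounds share one core. Compound 1 `O=C(O)CCCO/N=c1/ccn([C@@H]2O[C@H](COP(=O)(O)OP(=O)(O)OP(=O)(O)O)[C@@H](O)[C@H]2O)c(=O)[nH]1` gives 299 nM in a functional assay on 1321-N1 cells for agonist activity at P2Y purinoceptor 2 (Homo sapiens), read by scintillation counting and inositol phosphate accumulation (a lower number here means that less compound is needed, a higher number that more compound is needed for the effect), compound 2 `O=c1[nH]/c(=N\OCCCc2cccc(F)c2)ccn1[C@@H]1O[C@H](COP(=O)(O)OP(=O)(O)OP(=O)(O)O)[C@@H](O)[C@H]1O` gives 190 nM, and compound 3 `O=c1[nH]/c(=N\OCCCc2ccc(Br)cc2)ccn1[C@@H]1O[C@H](COP(=O)(O)OP(=O)(O)OP(=O)(O)O)[C@@H](O)[C@H]1O` gives 350 nM. Compound 3 sits beside both, since a 1.2-fold higher number from compound 1 to compound 3 (0.07 log units; within the scatter) and a 1.8-fold higher number from compound 2 to compound 3 (0.27 log units; within the scatter). Compound 4 `O=c1[nH]/c(=N\OCCCc2cccnc2)ccn1[C@@H]1O[C@H](COP(=O)(O)OP(=O)(O)OP(=O)(O)O)[C@@H](O)[C@H]1O` differs from compound 3 by pyridin-3-yl in place of 4-bromophenyl on a saturated chain carbon, three bonds along the chain from an oxygen. Among the compounds with values here, the steps that bear on this are those exchanging the group on that chain carbon: a 1.6-fold lower number from compound 1 to compound 2 (0.20 log units; within the scatter), a 1.2-fold higher number from compound 1 to compound 3 (0.07 log units; within the scatter) and a 1.8-fold higher number from compound 2 to compound 3 (0.27 log units; within the scatter), none of them beyond the scatter. He therefore expects no step beyond the scatter in this assay, a 1.2-fold lower number from compound 3 to compound 4 (0.07 log units; within the scatter). For compound 4 he estimates 300 nM, with a range from 120 nM to 750 nM.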

Compound 4, half-maximal effective concentration: 327 nM
Estimate against measurement, compound 4: 1.1-fold (0.04 log units) below, and the stated range covers the measured number.
By their numbers in this assay, from the lowest: compounds 2, 1, 4 and 3 (each within the scatter of the next).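

Within the data shown here, with pyridin-3-yl, the chain carbon now carries a ring with 1 hetero atom and 1 hydrogen-bond acceptor, and in this assay no step from the earlier groups lies beyond the scatter: against 4-bromophenyl (a 1.1-fold lower number from compound 3 to compound 4 (0.03 log units; within the scatter)), against 3-fluorophenyl (a 1.7-fold higher number from compound 2 to compound 4 (0.24 log units; within the scatter)) and against carboxy (a 1.1-fold higher number from compound 1 to compound 4 (0.04 log units; within the scatter)). Across these four compounds, then, this position has not separated the carbon-only rings, the pyridine ring and the carboxylic acid. No evidence at hand accounts for this result. From the compounds shown here alone, whether an amine, pyridin-4-yl or a longer chain here would produce a step beyond the scatter remains open.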